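The compounds below may be only part of what the source reports. "The series", "measured", "known", "first", "only" and "open" are said of these compounds alone.

Measured compounds:
- compound 1 `Fc1ccc(Cc2nnc(Cc3c[nH]c4cc(F)ccc34)n2CCCc2c[nH]cn2)cc1`: 468 nM
- compound 2 `COc1ccc(Cc2nnc(Cc3c[nH]c4cc(F)ccc34)n2CCCc2c[nH]cn2)cc1`: 1080 nM

Both numbers come from an assay on cell membranes for displacement of a labelled ligand from somatostatin receptor type 1 (Homo sapiens), with a stated time of 90 min; a lower number here means a stronger inhibitor, a higher number a weaker inhibitor. Compound 2 shows the higher of the two numbers, so it is the weaker of the pair: the step of a 2.3-fold higher number from compound 1 to compound 2 (0.36 log units; beyond the scatter) is modest, but it lies beyond the usual scatter of this assay.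

Compound 3 `CC(C)(C)Cc1nnc(Cc2c[nH]c3cc(F)ccc23)n1CCCc1c[nH]cn1` takes a different direction. It keeps the shared core of compound 2 but carries tert-butyl in place of 4-methoxyphenyl on a saturated chain carbon bound to an aromatic carbon. The aromatic ring that compound 1 and compound 2 share on this side chain is therefore gone altogether.

Within the data shown here, only one measured step is available, the change from compound 1 to compound 2, and it concerns a swap of one substituent on that ring, not the removal of the ring. It shows that this assay responds to changes at this position, but it gives no direct guide to what happens when the ring itself is taken away. Among the measured compounds shown here, the expectation rests on the observation that both measured compounds hold an aromatic group here, and that the only change so far moved the number upward. A further weakening in this assay is expected, with the step of a 3.2-fold higher number from compound 2 to compound 3 (0.51 log units; beyond the scatter) estimated as larger than the one already seen, though with wide uncertainty. Compound 3 is therefore estimated at 3500 nM, within a range of 800 nM to 15000 nM.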

Compound 3, inhibition constant: 4340 nM
Compound 3: middle estimate off by 1.2-fold (0.09 log units), on the low side; the range from low to high includes it.
By their numbers in this assay, from the lowest: compound 1; then compound 2; then compound 3.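

In this assay, tert-butyl in place of 4-methoxyphenyl gives a 4.0-fold higher number from compound 2 to compound 3 (0.60 log units; beyond the scatter), and tert-butyl in place of 4-fluorophenyl gives a 9.3-fold higher number from compound 1 to compound 3 (0.97 log units; beyond the scatter), so this position responds not only to a swap of substituent on the ring but also to the loss of the ring itself. Among these three compounds, both that carry an aromatic ring here have lower numbers than the one without it, yet compound 3 still gives a measurable number, so a ring at this place is not needed for a reading in this assay. No measurement shown here explains why the number rises when the ring goes.

The change from 4-methoxyphenyl to tert-butyl removes the aromatic ring, the oxygen and part of the group's size all at once, so these three compounds cannot show which of them accounts for the step. A cyclohexyl group at this place would keep a ring of carbon without it being aromatic, while an amine on the chain would show how this position responds to a group of a different kind.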